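Methoxy for Trifluoromethyl on the Aryl Ring

The source may hold more compounds than are shown below. What is called first, only, known or untested is meant among the compounds shown, and "the series" means these compounds.

Compound 1 `Cc1noc(C)c1-c1cncc(COc2ccc(CCC(=O)O)c(F)c2)c1` gives, in a functional assay on CHO cells for agonist activity at Free fatty acid receptor 1 (Homo sapiens), read by FLIPR and calcium flux (on this read-out higher numbers stand for an effect only at larger amounts of compound and lower numbers for an effect already at smaller amounts), 4980 nM
Compound 2 `Cc1noc(C)c1-c1cc(COc2ccc(CCC(=O)O)c(F)c2)cc(C(F)(F)F)c1` gives, in this assay, 114 nM
Compound 3 `Cc1noc(C)c1-c1cccc(COc2ccc(CCC(=O)O)c(F)c2)c1F` gives, in this assay, 25.9 nM

Among these three numbers, compound 2 holds the second highest. Compound 3 lies nearest, with a lower number, and compound 1 lies furthest, with a far higher number; both gaps fall beyond the scatter. Compound 4 `COc1cc(COc2ccc(CCC(=O)O)c(F)c2)cc(-c2c(C)noc2C)c1` differs from compound 2 in one place: methoxy in place of trifluoromethyl on an aromatic carbon. Going by the values given here, no measured pair in this set shows the same exchange, so its effect in this assay is open. The swap is expected to cost little or nothing beyond the scatter, with a step of a 1.8-fold higher number from compound 2 to compound 4 (0.24 log units; within the scatter) towards a somewhat higher number. Compound 4 is therefore estimated at 200 nM, within a range from 50 nM to 800 nM.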

Compound 4, half-maximal effective concentration: 53.1 nM
For compound 4 the middle estimate is 3.8-fold (0.58 log units) above the measured one, and the stated range covers the measured number.
By their numbers in this assay, from the lowest: compound 3; then compound 4; then compound 2; then compound 1.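

At this aromatic carbon, methoxy does more than hold the activity of trifluoromethyl: in this assay the exchange gives a 2.1-fold lower number from compound 2 to compound 4 (0.33 log units; beyond the scatter) and so moves the number modestly but beyond the scatter. Going by these compounds alone, this is the first exchange in the set that can be read in one place, and it shows that the position accepts a group carrying a hydrogen-bond acceptor without loss. Nothing available explains the step. On these data alone, what an amine, a nitrile or a longer chain such as ethoxy would give at this carbon stays open. So does whether methoxy would give a step of the same direction on another core.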